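Swapping Fluoro for Hydrogen on an Aromatic Ring

This account rests on a few compounds, and the source may have more. Where it says the series, first, only, none or still open, it means among the compounds named here.

In a functional assay on A549 cells (Homo sapiens) for antiproliferative activity, read by MTT assay, with a stated time of 72 h (a lower number here means a stronger inhibitor, a higher number a weaker inhibitor), compound 1 `CN1CCN(c2ccc(Nc3ncc4nc(Nc5ccccc5)n([C@H]5CCNC5)c4n3)cc2)CC1` has the entry "not determined" (no result reported). Compound 2 `CN1CCN(c2ccc(Nc3ncc4nc(Nc5ccccc5)n([C@@H]5CCNC5)c4n3)cc2)CC1` has the entry "not determined" (no result reported), so this pair offers no number to compare. Compound 3 `CN1CCN(c2ccc(Nc3ncc4nc(Nc5ccc(F)cc5)n([C@@H]5CCN(S(=O)(=O)C6CC6)C5)c4n3)cc2)CC1` reads > 10000 nM, which is a limit of this assay and not a number. Compound 4 `CN1CCN(c2ccc(Nc3ncc4nc(Nc5ccccc5)n([C@@H]5CCN(S(=O)(=O)C6CC6)C5)c4n3)cc2)CC1` carries hydrogen in place of fluoro on an aromatic carbon, para to a large group: hydrogen in place of fluoro on an aromatic carbon. Going by the values given here, no measured pair shows what such a change does in this assay. The expected change is a number no higher from compound 3 to compound 4 (the limit leaves the size open), meaning no step beyond the usual scatter in either direction. Compound 4 is estimated at 10000 nM, with an expected range from 3000 nM to 30000 nM.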

Compound 4, half-maximal inhibitory concentration: 2910 nM
Compound 4: middle estimate off by 3.4-fold (0.54 log units), on the high side, and the stated range ends above it.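

In this assay, going by these compounds alone, the first readable step at this position is an at least 3.4-fold lower number from compound 3 to compound 4 (0.53 log units; beyond the scatter), so removing fluoro from the 4-fluorophenyl group moves the series from no measurable potency to a real number. Compound 3 reads > 10000 nM, which is a limit and not a number, so the full size of the step stays open: the limit of > 10000 nM in this assay, at which 1 of the 4 values shown sits.

From the compounds shown here alone, whether chloro, methyl or methoxy on this same aromatic carbon would behave like hydrogen or like fluoro remains open. The effect of configuration cannot be read, as neither compound 1 nor compound 2 has a value: the fact that compounds 1 and 2 differ only in the configuration as drawn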